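The source may report more compounds than this note shows. Statements on the series, on what has been measured and on what is new or still open speak of the compounds shown alone.

For the measured compounds named here, in an ADME assay on microsomes from liver (Homo sapiens) for metabolic stability, read by LC-MS, with a stated time of 30 min, tested at 1 uM (on this read-out lower numbers stand for a less stable compound and higher numbers for a more stable compound), compound 2 (`O=C(NCc1ccc(S(=O)(=O)c2ccccc2)cc1)c1ccc2nncn2c1`) stands at 96% as the higher of the two numbers so far, and compound 1 (`O=C(NCc1ccc(S(=O)(=O)c2ccccc2)cc1)c1nc2cnccc2[nH]1`) stands at 73% on the same read-out. Compound 3 (`O=C(NCc1ccc(S(=O)(=O)c2ccccc2)cc1)c1cc2cnccc2[nH]1`) has not yet been measured and differs from compound 2 in one place, on a carbonyl carbon (a group of 9 heavy atoms (7 carbon, 2 nitrogen; one five-membered aromatic ring with 1 hetero atom, one six-membered aromatic ring with 1 hetero atom) in place of a group of 9 heavy atoms (6 carbon, 3 nitrogen; one five-membered aromatic ring with 3 hetero atoms, one six-membered aromatic ring with 1 hetero atom), on a carbonyl carbon). Going by the values given here, the one measured step that bears on this change is of modest size (a number 23 percentage points higher from compound 1 to compound 2 (beyond the scatter)) and falls on a carbonyl carbon too, where a group with a five-membered aromatic ring with 3 hetero atoms took the place of one with 2 hetero atoms. Compound 3 goes the opposite way on that count, to a five-membered aromatic ring with 1 hetero atom. Among the compounds with values here, a single step sets no trend, but with compound 1 at 73% as the only comparison, a fall of similar modest size, beyond the scatter, is expected in this assay for this change. The expected step is a number 24 percentage points lower from compound 2 to compound 3 (beyond the scatter) as an estimate only. Compound 3 is therefore estimated at 72% with an expected range from 50% to 90% in this measurement.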

Compound 3, percent of the compound remaining: 75%
For compound 3 the middle estimate is 3 percentage points below the measured one; the measured number falls inside the stated range.
By their numbers in this assay, from the lowest: compounds 1 and 3 (each within the scatter of the next); then compound 2.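

In this assay, the change on the carbonyl carbon now has a second reading: a group with a five-membered aromatic ring with 1 hetero atom, in place of the one with 3 hetero atoms, gives a number 21 percentage points lower from compound 2 to compound 3 (beyond the scatter). So the gap is no longer tied to compound 1 alone, while the groups with 1 and 2 hetero atoms in that ring cannot be told apart, with a number 2 percentage points higher from compound 1 to compound 3 (within the scatter), and among these three compounds only the group of compound 2 stands apart, not a steady rise with each added hetero atom. Nothing measured here explains this difference.

The compounds shown leave open whether the gap follows the hetero atoms of the five-membered ring or the hydrogen-bond count, as the group that leaves has 0 hydrogen-bond donors and the group that enters has 1 hydrogen-bond donor. They also leave open where a single phenyl ring, a pyridine ring or a group bearing a carboxylic acid on the same carbonyl carbon would stand in this assay.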